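This account rests on a few compounds, and the source may have more. Where it says the series, first, only, none or still open, it means among the compounds named here.

Of the compounds shown here, three have so far been measured in a functional assay on HepG2 cells (Homo sapiens) for inhibition, read by MTT assay, with a stated time of 24 h; on this read-out lower numbers stand for stronger inhibition and higher numbers for weaker inhibition. Compound 1 `O=C(COc1ccc(Cl)cc1)NCc1ccc(CNC(=O)COc2ccc(Cl)cc2)cc1` gives 26400 nM, compound 3 `C[C@]1(C(=O)NCCOc2ccc(C3CCCCC3)cc2)CO[C@@H](c2ccccc2)OC1` gives 32900 nM, and compound 2 `O=C(CNC(=O)c1cccnc1Cl)N/N=C/c1cccc(OCc2ccccc2Cl)c1` gives 3100 nM, the lowest of the three numbers, with the other two values standing beyond the scatter above it. Compound 4 `Cc1ccc(C(=O)NCC(=O)N/N=C/c2cccc(OCc3ccccc3Cl)c2)cc1` has not yet been measured. It differs from compound 2 in a single place: 4-methylphenyl in place of 2-chloropyridin-3-yl on a carbonyl carbon. Among the compounds with values here, no measured pair shows the effect of this change on its own, so the expectation leans on the value of compound 2. The step from compound 2 to compound 4 in this assay is expected to be modest, at most a little toward a weaker result, around a 1.5-fold higher number from compound 2 to compound 4 (0.16 log units; within the scatter). Compound 4 is therefore expected to give about 4500 nM, within a range from 1500 nM to 14000 nM.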

Compound 4, half-maximal inhibitory concentration: 47500 nM
Compound 4: the middle estimate sits 11-fold (1.02 log units) below what was measured; measured number outside the range, above it.
By their numbers in this assay, from the lowest: compound 2; then compounds 1, 3 and 4 (each within the scatter of the next).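

In this assay, the group on this carbonyl carbon proves to matter: placing 4-methylphenyl where 2-chloropyridin-3-yl stood gives a 15-fold higher number from compound 2 to compound 4 (1.19 log units; beyond the scatter), a large step. The two groups have the same number of heavy atoms, so size counted this way does not separate them. Nothing available explains the step.

The exchange removes the chlorine and the ring nitrogen and adds the methyl all at once, leaving the share of each unknown. A plain phenyl group, or a pyridine ring without chlorine, in this place would begin to separate them.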